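The source may report more compounds than this note shows. Statements on the series, on what has been measured and on what is new or still open speak of the compounds shown alone.

Measured compounds and their numbers:
compound 1 `CCOc1cc(=O)n(CCCO)c2c1CC(CC=C(C)C)C(C)(C)C2` gives 16.6% in a functional assay on PANC-1 cells (Homo sapiens) for inhibition, read by MTT assay, with a stated time of 24 h, tested at 10 uM; a higher number here means more inhibition at the concentration tested (going by the name of the read-out), a lower number less inhibition
compound 2 `CC(C)=CCC/C(C)=C/COc1cc(=O)n(CCCO)c2c1CC(CC=C(C)C)C(C)(C)C2` gives 18.4% in this assay
compound 3 `COc1ccc(OCCCOc2cc(=O)n(CCCO)c3c2CC(CC=C(C)C)C(C)(C)C3)cc1` gives 4.1% in this assay

Compound 2 holds the highest of the three numbers, though its gap to compound 1 is within the scatter (a number 1.8 percentage points higher from compound 1 to compound 2 (within the scatter)), so the two cannot be ranked against each other; only compound 3 stands apart, with a number 14.3 percentage points lower from compound 2 to compound 3 (beyond the scatter) and a number 12.5 percentage points lower from compound 1 to compound 3 (beyond the scatter).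

Compound 4 `COc1ccc(NC(=O)Oc2cc(=O)n(CCCO)c3c2CC(CC=C(C)C)C(C)(C)C3)cc1` is reached from compound 2 by one change, ((4-methoxyphenyl)carbamoyl in place of 3,7-dimethylocta-2,6-dien-1-yl on an oxygen on an aromatic ring). For the measured compounds named here, the measured step that bears most directly on it is the one from compound 2 to compound 3, a number 14.3 percentage points lower from compound 2 to compound 3 (beyond the scatter), where the same 3,7-dimethylocta-2,6-dien-1-yl chain on the oxygen on the aromatic ring also gave way to a group carrying a 4-methoxyphenyl ring. The step from compound 1 to compound 3, a number 12.5 percentage points lower from compound 1 to compound 3 (beyond the scatter), points the same way. Both of these changes lowered the read-out by a modest amount beyond the scatter, whereas the exchange of a methyl for the longer chain (a number 1.8 percentage points higher from compound 1 to compound 2 (within the scatter)) did not move it. A lowering step of similar, modest size is therefore expected for the change to compound 4, a number 11.4 percentage points lower from compound 2 to compound 4 (beyond the scatter). Compound 4 is estimated at 7%, with a range of 0% to 20%.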

Compound 4, a percentage reported as inhibition, at one concentration (the size of the read-out at that concentration, not a potency): 0%
For compound 4 the middle estimate is 7 percentage points above the measured one, and the stated range covers the measured number.
By their numbers in this assay, from the lowest: compounds 4 and 3 (each within the scatter of the next); then compounds 1 and 2 (each within the scatter of the next).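

For the compounds shown here, at the oxygen on an aromatic ring, (4-methoxyphenyl)carbamoyl is the first replacement here that is not joined through a saturated chain, and in this assay it gives a number 18.4 percentage points lower from compound 2 to compound 4 (beyond the scatter) and also a number 16.6 percentage points lower from compound 1 to compound 4 (beyond the scatter) as the step from the shorter group. Compound 4 and compound 3 lie within the scatter of each other, so in these two compounds the carbamoyl link and the propyl chain ending in a 4-methoxyphenoxy group cannot be told apart by this read-out. Among the four compounds, both that carry a 4-methoxyphenyl ring at this position stand beyond the scatter below compound 1 and compound 2, and none goes against this, while the change also brings in a hydrogen-bond donor that compound 3 lacks without any separable effect on the number.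

From the compounds shown here alone, whether the lowering follows the 4-methoxyphenyl ring or simply the size of the group stays open; a phenylcarbamoyl without the methoxy group and an ethylcarbamoyl would bear on this. Whether any group at this oxygen raises the read-out beyond that of compound 1 also stays open, and no measurement speaks to the reason for the fall at this position.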